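A few compounds are considered here, and "the series" means these few. Any claim that something is new, unique, unknown or untested is made for them only; others in the source may bear on it.

Among the compounds with values here, compound 2 `CCC1C(=O)N(C)c2cnc(-n3ccc4cc(C(=O)NCC(C)C)ccc43)nc2N1c1ccn(C)n1` is the one compound here with a measured number: in a functional assay on Huh-7 cells (Homo sapiens) for antiproliferative activity, read by CCK-8 assay, with a stated time of 72 h (on this read-out lower numbers stand for stronger inhibition of growth and higher numbers for weaker inhibition of growth), compound 2 gives 5070 nM. Compound 1 `CCC1C(=O)N(C)c2cnc(Nc3ccc(S(=O)(=O)NCCCO)cc3)nc2N1c1ccn(C)n1` is reported in this assay as "not active" (no number reported), without a number. Within the data shown here, compound 3 `CC[C@@H]1C(=O)N(C)c2cnc(-n3ccc4cc(C(=O)NCC(C)C)ccc43)nc2N1C1CCCC1` is likewise reported in this assay as "not active" (no number reported), without a number, so no step between two measured compounds can be drawn. Compound 4 `CCC1C(=O)N(C)c2cnc(-n3ccc4cc(F)ccc43)nc2N1c1ccn(C)n1` differs from compound 2 in one place: fluoro in place of isobutylcarbamoyl on an aromatic carbon. Among the measured compounds shown here, with no measured pair to lean on, the expectation rests on compound 2 alone, whose 5070 nM already sits at the weak end. The change is expected to move toward weaker inhibition, by a step of a 3.0-fold higher number from compound 2 to compound 4 (0.47 log units; beyond the scatter), clearly beyond the scatter, with a real chance that no number is obtained. Compound 4 is therefore estimated at 15000 nM, ranging from 4000 nM to 60000 nM.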

Compound 4, concentration for 50% growth inhibition: "not active" (no number reported)
Compound 4 has no reported number here; the estimate stays without a comparison.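

Within the data shown here, compound 4 has no number in this assay, so no step from compound 2 to compound 4 can be read, and no measured evidence bears on this result. The compounds shown leave open how much the isobutylcarbamoyl group contributes to the growth inhibition of compound 2.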